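The source may hold more compounds than are shown below. What is called first, only, known or untested is meant among the compounds shown, and "the series" means these compounds.

Measured compounds in a functional assay on HT-29 cells (Homo sapiens) for cytotoxicity, read by MTT assay, with a stated time of 72 h; on this read-out higher numbers stand for weaker inhibition of growth and lower numbers for stronger inhibition of growth:
Compound 1 `COc1ccc(CNc2nc([SeH])nc3ccccc23)cc1` gives > 100000 nM, which is a limit of the assay and not a number.
Compound 2 `CSc1ccc(CNc2nc([SeH])nc3ccccc23)cc1` gives > 100000 nM, again only a limit.
Compound 3 `COc1ccc(CNc2nc(SC)nc3ccccc23)cc1` gives > 100000 nM, also only a limit.

Compound 4 `CSc1ccc(CNc2nc(SC)nc3ccccc23)cc1` has not yet been measured in this assay. Compounds 1 and 2 differ by methylsulfanyl in place of methoxy on an aromatic carbon, and the step that the two limits leave unreadable from compound 1 to compound 2 cannot be read, since both values sit at the limit of > 100000 nM in this assay, at which 3 of the 3 values shown sit. Compounds 1 and 3 differ in their cores by a group of 2 heavy atoms (1 carbon, 1 sulfur; no ring) in place of one selenium atom, on an aromatic carbon; the step that the two limits leave unreadable from compound 1 to compound 3 is equally unreadable, as both values again sit at the limit of > 100000 nM in this assay, at which 3 of the 3 values shown sit. Compound 4 differs from compound 3 by methylsulfanyl in place of methoxy on an aromatic carbon, the same change as that from compound 1 to compound 2, at the same place. Since the earlier instance of this change left both compounds at the limit of > 100000 nM in this assay, at which 3 of the 3 values shown sit, and compound 3 sits there as well, compound 4 is expected to show a step of a number no higher from compound 3 to compound 4 (the limit leaves the size open), that is, no movement that the assay could resolve. Compound 4 is therefore estimated at 100000 nM, most probably reported once more only as a limit, with a range from 50000 nM to 300000 nM.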

Compound 4, concentration for total growth inhibition: > 100000 nM
Compound 4 was reported as a limit (the forecaster's own chance of this, stated with the estimate: 85%); the middle value lies on the limit itself.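

Neither the step from compound 3 to compound 4 nor that from compound 2 to compound 4 can be read in this assay, since all these values are limits and not numbers: the limit of > 100000 nM in this assay, at which 4 of the 4 values shown sit.

The compounds shown leave open how strongly each inhibits growth, and so whether methylsulfanyl in place of methoxy, or the group replacing selenium, changes it at all.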